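This account rests on a few compounds, and the source may have more. Where it says the series, first, only, none or still open, it means among the compounds named here.

Measured compounds:
compound 1, `Cc1nc2ccccc2c(=O)n1NC(=O)NC(C)(C)C`, giving 51%
compound 2, `CC(=O)Nc1ccc(S(=O)(=O)Nn2c(C)nc3ccccc3c2=O)cc1`, giving 59.2%
compound 3, `CC(C)(C)NC(=O)Nn1c(CO[N+](=O)[O-])nc2ccccc2c1=O`, giving 43.7%

These three were compared in a functional assay on the whole organism (strain Sprague-Dawley) for inhibition, with Rattus norvegicus as the target, read by paw edema, with stated times of 30 min and 3 h, at a dose of 80 mg/kg by the oral route; a lower number here means less inhibition, a higher number more inhibition at the dose given (going by the name of the read-out). Compound 2 and compound 1 share no single counted difference; how their two cores differ is not broken down here. Compound 3 carries the change nitrooxy in place of hydrogen on a saturated chain carbon bound to an aromatic carbon relative to compound 1, and that step, a number 7.3 percentage points lower from compound 1 to compound 3 (within the scatter), stays within the scatter; the numbers of compound 1 and compound 2 also lie within the scatter of each other, while compound 3 reads lower than compound 2 by a margin beyond it.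

Compound 4, `CC(=O)Nc1ccc(S(=O)(=O)Nn2c(CO[N+](=O)[O-])nc3ccccc3c2=O)cc1`, has not been measured. It differs from compound 2 by nitrooxy in place of hydrogen on a saturated chain carbon bound to an aromatic carbon, the same change, at the same place, as that from compound 1 to compound 3. Because a number 7.3 percentage points lower from compound 1 to compound 3 (within the scatter) was flat within the scatter, compound 4 is expected to move by about a number 7.2 percentage points lower from compound 2 to compound 4 (within the scatter) in this assay. Compound 4 is therefore estimated at 52%, with a likely range of 40% to 64%.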

Compound 4, a percentage reported as inhibition, in the whole organism at one dose (the size of the read-out at that dose, not a potency): 64.8%
Estimate against measurement, compound 4: 12.8 percentage points below; measured number above the stated range.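

In this assay, the change from methyl to (nitrooxy)methyl on the sulfonamide-bearing core gives a number 5.6 percentage points higher from compound 2 to compound 4 (within the scatter), so on this core too the step stays small. Set beside the earlier step, it points the other way, but the two do not differ by more than repeated measurements allow: the same change on two cores in this assay, a number 7.3 percentage points lower (within the scatter) from compound 1 to compound 3 and a number 5.6 percentage points higher (within the scatter) from compound 2 to compound 4, 12.9 percentage points apart, within the scatter of two such steps. This shows that the change carries from one core to the other with no clear effect on the read-out at this dose; it does not show that the two cores respond differently, nor that the change would stay without effect at other doses or times.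

The compounds shown leave open whether another group on that chain carbon, such as an amine, a carboxylic acid or a longer chain carrying nitrooxy, would read differently from methyl. They also leave open how the change behaves on any further core.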